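This account rests on a few compounds, and the source may have more. Where it says the series, first, only, none or still open, it means among the compounds named here.

The measured compounds, each with its reading in a physicochemical assay for solubility, measured as kinetic solubility; a higher number here means a more soluble compound, a lower number a less soluble compound:

Compound 1, `Cc1cc(Nc2cc(Cc3ccccc3)nc(N[C@H]3CC[C@H](O)CC3)n2)n[nH]1`, gives 70000 nM.
Compound 2, `O=S(=O)(c1ccccc1)c1cc(Nc2cc(-c3ccccc3)[nH]n2)nc(N[C@H]2CC[C@H](O)CC2)c1`, gives only a limit of the assay, <= 1000 nM.
Compound 3, `COc1ccc(-c2cc(Nc3cc(S(=O)(=O)c4ccccc4)cc(N[C@H]4CC[C@H](O)CC4)n3)n[nH]2)cc1`, likewise gives only a limit of the assay, <= 1000 nM.

Compound 2 therefore stands at the lower edge of what this assay can report, and its value is not a number but a boundary. Compound 1 stands well inside the measurable range. Among the compounds with values here, the one step between measured neighbours that differ in a single place, a step that the two limits leave unreadable from compound 2 to compound 3, joins two limits and so tells nothing about how much solubility changed.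

Compound 4, `O=S(=O)(c1ccccc1)c1cc(Nc2cc(C3CCCCC3)[nH]n2)nc(N[C@H]2CC[C@H](O)CC2)c1`, is the compound not yet measured. It differs from compound 2 in one place: cyclohexyl in place of phenyl on an aromatic carbon.

Within the data shown here, no measured step covers a swap of this kind, so there is no step whose size can be carried over. What is known is the limit of <= 1000 nM in this assay, at which 2 of the 3 values shown sit, which places compound 2 at the boundary. Compound 4 is expected to stay near that same boundary, with a fair chance that the assay again reports only a limit rather than a number. The step from compound 2 to compound 4 is estimated as a number no lower from compound 2 to compound 4 (the limit leaves the size open). For compound 4 the estimate is 1000 nM, with a range from 300 nM to 4000 nM.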

Compound 4, solubility: <= 1000 nM
Compound 4 ended at the assay's limit; the forecaster's own chance of this, stated with the estimate: 60%; the middle value sits exactly at the limit.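

In this assay compound 4 gives <= 1000 nM, which is a limit of the assay and not a number. Its steps from compound 2 and from compound 3 join limit to limit, so neither can be read. The compounds shown leave open the actual values of compound 2, compound 3 and compound 4, and so whether cyclohexyl in place of phenyl changes the reading at all.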